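Amine nitrogen substituents: from compound 3 to compound 4

The source may report more compounds than this note shows. Statements on the series, on what has been measured and on what is new or still open speak of the compounds shown alone.

Measured in a functional assay on HeLa cells (Homo sapiens) for inhibition, read by sulforhodamine B assay; a lower number here means a stronger inhibitor, a higher number a weaker inhibitor:
- compound 1 `O=C1C(NC2CC2)=CC(=O)c2c1nc1n2[C@H]2OC[C@@H](O)[C@H]2OC1`: > 16000 nM (a limit)
- compound 2 `CCOc1ccc(NC2=CC(=O)c3c(nc4n3[C@H]3OC[C@@H](O)[C@H]3OC4)C2=O)cc1`: 14400 nM
- compound 3 `COc1cccc(NC2=CC(=O)c3c(nc4n3[C@H]3OC[C@@H](O)[C@H]3OC4)C2=O)c1`: > 8000 nM (a limit)

Compound 3 stands only at a limit, > 8000 nM. Compound 4 `CCCc1ccc(NC2=CC(=O)c3c(nc4n3[C@H]3OC[C@@H](O)[C@H]3OC4)C2=O)cc1` carries 4-propylphenyl in place of 3-methoxyphenyl on an amine nitrogen. Among the measured compounds shown here, two measured steps bear on this change: an at least 1.1-fold lower number from compound 1 to compound 2 (0.04 log units; that floor lies within the scatter) and a step that the limit leaves unreadable from compound 2 to compound 3. Neither gives a readable size beyond the scatter. For the measured compounds named here, the only compound with a number is compound 2 at 14400 nM, and the expectation rests on it. In this assay the expected step is a step that the limit leaves unreadable from compound 3 to compound 4, so nothing beyond the scatter is expected in either direction. For compound 4 the estimate is 12000 nM, with an expected range of 5000 nM to 25000 nM.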

Compound 4, half-maximal inhibitory concentration: 6030 nM
For compound 4 the middle estimate is 2.0-fold (0.30 log units) above the measured one, within the range that was stated.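

In this assay, propyl in place of ethoxy on an aromatic carbon gives a step between two real numbers that lies beyond the scatter: a 2.4-fold lower number from compound 2 to compound 4 (0.38 log units; beyond the scatter). The change from the cyclopropyl amine also clears the scatter, an at least 2.6-fold lower number from compound 1 to compound 4 (0.42 log units; beyond the scatter), while the change from 3-methoxyphenyl does not, an at least 1.3-fold lower number from compound 3 to compound 4 (0.12 log units; that floor lies within the scatter). These last two steps are floors only, as compound 1 and compound 3 each stand at a limit.

Open, on these data alone, is whether a butyl chain or a carboxylic acid in place of propyl would move the number further.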